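Swapping a Halogenated Ring on a Second Core

The source may hold more compounds than are shown below. What is called first, only, known or untested is meant among the compounds shown, and "the series" means these compounds.

Compound 1 `COc1cc(/C=C2\CN(C)C/C(=C\c3ccc(Br)cc3)C2=O)cc(OC)c1OC` and compound 2 `COc1cc(/C=C2\CN(C)C/C(=C\c3ccc(Cl)cc3Cl)C2=O)cc(OC)c1OC` share one core and differ in a single place: 2,4-dichlorophenyl in place of 4-bromophenyl on a double-bonded chain carbon bound to a double-bonded ring carbon. In a functional assay on THP-1 cells (Homo sapiens) for cytotoxicity, read by MTT assay, with a stated time of 24 h (a higher number here means a weaker inhibitor, a lower number a stronger inhibitor), compound 1 gives 5330 nM, and compound 2 gives 5020 nM, so the change made a 1.1-fold lower number from compound 1 to compound 2 (0.03 log units; within the scatter). Compound 3 `CN1C/C(=C\c2ccc(Br)cc2)C(=O)/C(=C/c2cccc([N+](=O)[O-])c2)C1` is built on a different core; how its core differs from that of compound 1 is not broken down here. In this assay compound 3 gives 7690 nM, a number that sits within the scatter of both compound 1 and compound 2. Compound 4 `CN1C/C(=C\c2cccc([N+](=O)[O-])c2)C(=O)/C(=C/c2ccc(Cl)cc2Cl)C1` has not yet been measured in this assay. It differs from compound 3 by the same change seen between compound 1 and compound 2: 2,4-dichlorophenyl in place of 4-bromophenyl on a double-bonded chain carbon bound to a double-bonded ring carbon. Because that change made a 1.1-fold lower number from compound 1 to compound 2 (0.03 log units; within the scatter) on the first core, a similarly small step is expected on the second core, a 1.1-fold lower number from compound 3 to compound 4 (0.02 log units; within the scatter). This expectation rests on a single earlier pair, so it is held loosely. Compound 4 is therefore estimated to give 7300 nM in this assay, most likely between 3600 nM and 15000 nM.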

Compound 4, half-maximal inhibitory concentration: 3560 nM
Compound 4: the middle estimate sits 2.1-fold (0.31 log units) above what was measured, and the stated range ends above it.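

In this assay, putting 2,4-dichlorophenyl in place of 4-bromophenyl on the second core gave a 2.2-fold lower number from compound 3 to compound 4 (0.33 log units; beyond the scatter), a modest step. Set beside the earlier step, the result on the two cores cannot be told apart: the same change on two cores in this assay, a 1.1-fold lower number (0.03 log units; within the scatter) from compound 1 to compound 2 and a 2.2-fold lower number (0.33 log units; beyond the scatter) from compound 3 to compound 4, 2.0-fold (0.31 log units) apart, within the scatter of two such steps. Within the data shown here, this gives no sign that the core alters what the change does, but with only one pair on each core it does not show that the step carries over exactly, nor that it would hold on any further core.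

The compounds shown leave open whether the same change behaves alike when an amine or a carboxylic acid stands in place of the nitro group on the other aromatic ring. The change also removes a bromine and adds two chlorines in one move, and a phenyl ring bearing a single chlorine would be needed to pull those two parts apart.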